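One Chlorine, Two Compounds: Testing a Repeated Change

A few compounds are considered here, and "the series" means these few. Any claim that something is new, unique, unknown or untested is made for them only; others in the source may bear on it.

Compound 1 `CC1CCCC(Nc2ncnc3c2nnn3Cc2ccccc2)C1` and compound 2 `CC1CCCC(Nc2ncnc3c2nnn3Cc2ccccc2Cl)C1` share a core and differ in one spot only: chloro in place of hydrogen on an aromatic carbon. In an assay on cell membranes for binding affinity to adenosine receptor A1 (Bos taurus), read by radioligand binding (on this read-out lower numbers stand for stronger inhibition and higher numbers for weaker inhibition), compound 1 gives 770 nM, and compound 2 gives 102 nM. The step of a 7.5-fold lower number from compound 1 to compound 2 (0.88 log units; beyond the scatter) is a clear gain in affinity.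

Compound 3 `O=[N+]([O-])c1ccc(CNc2ncnc3c2nnn3Cc2ccccc2)cc1` carries a different group on the shared core; how its core differs from that of compound 1 is not broken down here. In this assay compound 3 reaches only a limit, > 1000 nM. Compound 4 `O=[N+]([O-])c1ccc(CNc2ncnc3c2nnn3Cc2ccccc2Cl)cc1` has not yet been measured; it is built from compound 3 by the same change, (chloro in place of hydrogen on an aromatic carbon), made at a place described in exactly the same words as before.

Because the limit of > 1000 nM in this assay, at which 1 of the 3 values shown sits, holds for compound 3, the starting point is not a number, and only the size of the step from compound 1 to compound 2 offers a guide. The step expected here is a number no higher from compound 3 to compound 4 (the limit leaves the size open), resting on a 7.5-fold lower number from compound 1 to compound 2 (0.88 log units; beyond the scatter). Compound 4 is expected to land near 1000 nM, between 200 nM and 5000 nM.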

Compound 4, inhibition constant: > 1000 nM
Compound 4 was reported as a limit; the forecaster's own chance of this, stated with the estimate: 45%; the middle value lies on the limit itself.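

In this assay compound 3 stands only as a limit, > 1000 nM. Compound 4 is also only a limit, > 1000 nM. Among the compounds shown here, with no number on either side, no step between compound 3 and compound 4 can be read. From the compounds shown here alone, whether chloro in place of hydrogen lowers the number for this pair, as it did for compound 1 and compound 2, stays open.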